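The source may hold more compounds than are shown below. What is called first, only, known or untested is meant among the compounds shown, and "the series" means these compounds.

Measured compounds:
- compound 1 `N/C(=N\NC(=S)N1CCCCCC1)c1ccccn1` gives 82.9% in a functional assay on HeLa cells (Homo sapiens) for cytotoxicity, read by MTT assay, with a stated time of 72 h, tested at 30 uM; a lower number here means less inhibition of growth, a higher number more inhibition of growth at the concentration tested
- compound 2 `Cc1ccnc(/C(N)=N/NC(=S)N2CCCCCC2)c1` gives 69.9% in this assay

Compound 1 stands highest of the two numbers shown, with compound 2 its nearest neighbour. Compound 3 `Cc1cccc(/C(N)=N/NC(=S)N2CCCCCC2)n1` is not yet measured. It differs from compound 1 by methyl in place of hydrogen on an aromatic carbon, the methyl sitting next to the ring nitrogen and meta to a large group. Among the measured compounds shown here, the one step that bears on this is the change a number 13 percentage points lower from compound 1 to compound 2 (beyond the scatter), where a methyl entered the same ring at another carbon. A modest fall is therefore expected here too, a number 12.9 percentage points lower from compound 1 to compound 3 (beyond the scatter). Compound 3 is estimated at 70%, between 55% and 85%.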

Compound 3, percent growth inhibition at one concentration: 81.2%
The estimate for compound 3 lay 11.2 percentage points below the measured number; the range from low to high includes it.
By their numbers in this assay, from the lowest: compound 2; then compounds 3 and 1 (each within the scatter of the next).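

In this assay, methyl in place of hydrogen next to the ring nitrogen gives a number 1.7 percentage points lower from compound 1 to compound 3 (within the scatter), whereas methyl at another ring carbon gave a number 13 percentage points lower from compound 1 to compound 2 (beyond the scatter). Among these compounds, then, the outcome of adding this one small group depends on which ring carbon carries it. Nothing measured here explains that difference. Going by these compounds, it remains open whether a longer chain such as ethyl at this same carbon would also leave the number within the scatter of compound 1, and whether a methoxy group or an amine would do the same.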